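Replacing an Octyl Chain with a 4-Bromophenyl Group

The source may report more compounds than this note shows. Statements on the series, on what has been measured and on what is new or still open speak of the compounds shown alone.

Compound 1 `O=c1cc(Cn2cc(CCCO)nn2)c2ccc(O)cc2o1` in a functional assay on A549 cells (Homo sapiens) for inhibition, read by MTT assay, with a stated time of 72 h (on this read-out lower numbers stand for stronger inhibition and higher numbers for weaker inhibition), gives 96200 nM.
Compound 2 `CCCCCCCCc1cn(Cc2cc(=O)oc3cc(O)ccc23)nn1` in this assay gives 46000 nM.

Compound 2 stands lowest of these two numbers, with compound 1 the nearest. The step to compound 3 `O=c1cc(Cn2cc(-c3ccc(Br)cc3)nn2)c2ccc(O)cc2o1` is 4-bromophenyl in place of octyl on an aromatic carbon. For the measured compounds named here, the only measured step, a 2.1-fold lower number from compound 1 to compound 2 (0.32 log units; beyond the scatter), concerns a change along a saturated chain and bears only loosely on swapping a chain for an aromatic ring. No step beyond the scatter is therefore expected for a 1.1-fold higher number from compound 2 to compound 3 (0.04 log units; within the scatter). Compound 3 is estimated at 50000 nM, within 15000 nM to 150000 nM.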

Compound 3, half-maximal inhibitory concentration: 32300 nM
For compound 3 the middle estimate is 1.5-fold (0.19 log units) above the measured one, and the stated range covers the measured number.
By their numbers in this assay, from the lowest: compounds 3 and 2 (each within the scatter of the next); then compound 1.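

Putting 4-bromophenyl in place of octyl gives a 1.4-fold lower number from compound 2 to compound 3 (0.15 log units; within the scatter) in this assay, so on this aromatic carbon a six-membered aromatic ring and a long saturated chain cannot be told apart on this read-out. Against the 3-hydroxypropyl group, the same ring gives a 3.0-fold lower number from compound 1 to compound 3 (0.47 log units; beyond the scatter), which places it with octyl, apart from compound 1. Nothing measured here offers an explanation for either step. Still open, going by these compounds, is whether an amine, a carboxylic acid or a plain phenyl at this carbon would shift the number further.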